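Polyamine-linked chalcones in a cell growth assay

The compounds below may be only part of what the source reports. "The series", "measured", "known", "first", "only" and "open" are said of these compounds alone.

Measured so far:
compound 1 `COc1ccc(/C=C/C(=O)c2cc(OC)c(OC)c(OC)c2)cc1OCCCC(=O)NCCCCN(CCCN)CCCCNCCCN`, 29500 nM
compound 2 `COc1cc(C(=O)/C=C/c2ccc(OCCCC(=O)NCCCCNCCCN)cc2)cc(OC)c1OC`, 20000 nM
compound 3 `COc1ccc(/C=C/C(=O)c2cc(OC)c(OC)c(OC)c2)cc1OCCCC(=O)NCCCCNCCCN`, 38000 nM

All three were read in a functional assay on HCT-116 cells (Homo sapiens) for antiproliferative activity, read by MTT assay, with a stated time of 48 h; a lower number here means a stronger inhibitor, a higher number a weaker inhibitor. Compound 1 and compound 3 share a core, and compound 2 carries the other core; the difference between the two cores is not broken down here. Compound 2 gives the lowest of the three numbers, but its distances to compound 1 and to compound 3 both lie within the scatter, so no order among them is claimed.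

The change from compound 3 to compound 1, (4-((3-aminopropyl)amino)butyl in place of hydrogen on an amine nitrogen), gave a 1.3-fold lower number from compound 3 to compound 1 (0.11 log units; within the scatter). Compound 4 `COc1cc(C(=O)/C=C/c2ccc(OCCCC(=O)NCCCCN(CCCN)CCCCNCCCN)cc2)cc(OC)c1OC` is not yet measured; it differs from compound 2 by 4-((3-aminopropyl)amino)butyl in place of hydrogen on an amine nitrogen, the same change at the same kind of place. The step from compound 2 to compound 4 in this assay is expected to be about a 1.3-fold lower number from compound 2 to compound 4 (0.10 log units; within the scatter), resting on the small step seen from compound 3 to compound 1 a 1.3-fold lower number from compound 3 to compound 1 (0.11 log units; within the scatter). Compound 4 is therefore estimated at 16000 nM, with a likely range from 7000 nM to 35000 nM.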

Compound 4, half-maximal inhibitory concentration: 75400 nM
Estimate against measurement, compound 4: 4.7-fold (0.67 log units) below; measured number outside the range, above it.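

In this assay, 4-((3-aminopropyl)amino)butyl in place of hydrogen on the amine nitrogen gave a 3.8-fold higher number from compound 2 to compound 4 (0.58 log units; beyond the scatter), so the change did not carry over unchanged from one core to the other: the same change on two cores in this assay, a 1.3-fold lower number (0.11 log units; within the scatter) from compound 3 to compound 1 and a 3.8-fold higher number (0.58 log units; beyond the scatter) from compound 2 to compound 4, 4.9-fold (0.69 log units) apart, beyond the scatter of two such steps

In this series, the outcome of the change therefore depends on the core it is made on. For the compounds shown here, with only one pair on each core, this does not show which feature of the cores is responsible, nor how the change would behave on any other core.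

The compounds shown leave open whether a shorter group on the same nitrogen, such as 3-aminopropyl, would separate the two cores in the same way. On these data alone, a longer polyamine chain also remains open.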